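The source may hold more compounds than are shown below. What is called first, only, known or untested is meant among the compounds shown, and "the series" means these compounds.

Compound 1 `COc1cc(C(N)=O)cc2nc(NC(=O)c3cccnn3)n(CCCNC(=O)OCc3ccccc3)c12` and compound 2 `COc1cc(C(N)=O)cc2nc(NC(=O)c3cc4ccccc4n3C)n(CCCNC(=O)OCc3ccccc3)c12` share a core and differ only at the group on the carbonyl carbon. In an assay for activation of interferon regulatory factor 3 (Homo sapiens), read by a luciferase reporter, with a stated time of 20 h (on this read-out lower numbers stand for an effect already at smaller amounts and higher numbers for an effect only at larger amounts of compound), compound 1 gives > 100000 nM, a limit of the assay rather than a number. In this assay compound 2 likewise gives > 100000 nM, again a limit. The step that the two limits leave unreadable from compound 1 to compound 2 therefore cannot be read, as the limit of > 100000 nM in this assay, at which 2 of the 2 values shown sit, shows. Compound 3 `COc1cc(C(N)=O)cc2nc(NC(=O)c3cccn3C)n(CCCNC(=O)OCc3ccccc3)c12` carries 1-methyl-1H-pyrrol-2-yl in place of 1-methyl-1H-indol-2-yl on a carbonyl carbon. With both neighbours at the limit, compound 3 is expected in this assay at 150000 nM, within 30000 nM to 1000000 nM, a step estimated as a step that the limit leaves unreadable from compound 2 to compound 3.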

Compound 3, half-maximal effective concentration: > 100000 nM
Compound 3 ended at the assay's limit; the forecaster's own chance of this, stated with the estimate: 75%; the middle value lies beyond the limit too.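

Compound 3, like compound 1 and compound 2, stands at a limit of this assay, so no step among the three can be read: the limit of > 100000 nM in this assay, at which 3 of the 3 values shown sit.

The compounds shown leave open whether any group on the carbonyl carbon gives a measurable value in this assay.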